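The compounds below may be only part of what the source reports. "The series", "measured", "known", "first", "only" and "open" are said of these compounds alone.

Compound 1 `N=C(NCc1ccc(O)cc1)[C@@H]1CCC(=O)N1Cc1ccccc1` carries an unsubstituted benzyl group on its shared core. In a functional assay on SH-SY5Y cells (Homo sapiens) for cytotoxicity, read by MTT assay, with stated times of 8 h, 30 min and 12 h, tested at 5 uM (a higher number here means a stronger effect of the compound at the concentration tested, a lower number a weaker effect), compound 1 gives 37.6%. Compound 2 `N=C(NCc1ccc(O)cc1)[C@@H]1CCC(=O)N1Cc1ccc([N+](=O)[O-])cc1` differs from it only in a nitro group on the benzyl ring, and in this assay compound 2 gives 34.5%. The step of a number 3.1 percentage points lower from compound 1 to compound 2 (within the scatter) shows that adding the nitro group changed little. For the measured compounds named here, compound 2 therefore sits close beside compound 1, the only other measured compound, and the gap between them is within the scatter.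

Compound 3 `Cc1ccc(CN2C(=O)CC[C@H]2C(=N)NCc2ccc(O)cc2)cc1` is the next member. Its difference from compound 2 is methyl in place of nitro on an aromatic carbon. Going by the values given here, the only measured step that bears on this change is the step from hydrogen to nitro, a number 3.1 percentage points lower from compound 1 to compound 2 (within the scatter), which lay within the scatter. Since exchanging hydrogen for nitro at this aromatic carbon made no clear difference, a methyl at the same carbon is not expected to either, so the expected step of a number 1.5 percentage points higher from compound 2 to compound 3 (within the scatter) is none beyond the scatter. Compound 3 is therefore estimated at 36%, with a range from 26% to 46%.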

Compound 3, a percentage reported as activity, at one concentration (the size of the read-out at that concentration, not a potency): 23.8%
Compound 3: the middle estimate sits 12.2 percentage points above what was measured, outside the stated range (below it).
By their numbers in this assay, from the lowest: compound 3; then compounds 2 and 1 (each within the scatter of the next).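

This aromatic carbon, para to a large group, is not indifferent to what it carries: in this assay, methyl in place of nitro gives a number 10.7 percentage points lower from compound 2 to compound 3 (beyond the scatter), and methyl in place of hydrogen gives a number 13.8 percentage points lower from compound 1 to compound 3 (beyond the scatter). Hydrogen and nitro had stayed within the scatter of each other, so that first pair gave no sign that a change here could move the read-out, whereas methyl sets compound 3 apart as the lowest of the three. Nothing available explains why methyl differs from the other two groups.

On these data alone, whether this lower read-out belongs to methyl alone or extends to a longer chain such as ethyl remains open. So does whether an amine or a methoxy group on the same carbon would read like hydrogen and nitro or like methyl.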